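Replacing Bromo with Dimethylamino

A few compounds are considered here, and "the series" means these few. Any claim that something is new, unique, unknown or untested is made for them only; others in the source may bear on it.

In a functional assay on PC-3 cells (Homo sapiens) for antiproliferative activity, read by MTT assay, with a stated time of 48 h (a higher number here means a weaker inhibitor, a lower number a stronger inhibitor), compound 1 `Cc1cc(Br)c2nc(-c3nnc(-c4ccc(Cl)cc4)o3)cn2c1` gives 42000 nM and compound 2 `Cc1cc(Br)c2nc(-c3nnc(-c4ccc(Br)cc4)o3)cn2c1` gives 24500 nM as its value. Within the data shown here, the only measured step is a 1.7-fold lower number from compound 1 to compound 2 (0.23 log units; within the scatter) for bromo in place of chloro, so compound 2 stands level with compound 1. Among the measured compounds shown here, compound 3 `Cc1cc(Br)c2nc(-c3nnc(-c4ccc(N(C)C)cc4)o3)cn2c1` has dimethylamino in place of bromo on an aromatic carbon as its single change. One swap between two halogens is a thin guide to this different group, so no step beyond the scatter is expected in this assay here. The expected change is a 1.0-fold higher number from compound 2 to compound 3 (0.01 log units; within the scatter) on this estimate. For compound 3 the estimated value is 25000 nM with a range from 8000 nM to 70000 nM as its likely span.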

Compound 3, half-maximal inhibitory concentration: 11200 nM
Beside the measured number, compound 3's estimate is 2.2-fold (0.35 log units) above it, within the range that was stated.
By their numbers in this assay, from the lowest: compound 3; then compounds 2 and 1 (each within the scatter of the next).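

In this assay the swap between two halogens stayed within the scatter, but this aromatic carbon, para to a large group, does respond to a group of another kind: dimethylamino gives a 2.2-fold lower number from compound 2 to compound 3 (0.34 log units; beyond the scatter) and also a 3.8-fold lower number from compound 1 to compound 3 (0.57 log units; beyond the scatter) so the position is not indifferent to what sits there, though both steps are modest. Nothing available explains this shift.

Going by these compounds, whether the gain follows the nitrogen or the larger group stays open. A plain amino group or a methoxy group at this position would help to separate the two.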